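The source may hold more compounds than are shown below. What is called first, only, known or untested is meant among the compounds shown, and "the series" means these compounds.

Measured so far in a functional assay on the whole organism with Scenedesmus acutus as the target, with a stated time of 20 h; on this read-out lower numbers stand for stronger inhibition and higher numbers for weaker inhibition:
- compound 1 `S=c1n(-c2ccc(Cl)cc2)c(=S)n2n1CCCC2` gives 50.1 nM
- compound 2 `S=c1n(-c2ccccc2)c(=S)n2n1CCCC2` gives 2040 nM
- compound 3 `S=c1s/c(=N\c2ccc(OCc3ccc(Cl)cc3)cc2)n2n1CCCC2` gives 120 nM

Compound 1 holds the lowest of the three numbers, with compound 3 nearest and compound 2 furthest. Compound 4 `Cc1cc(Cl)ccc1-n1c(=S)n2n(c1=S)CCCC2` is still unmeasured and differs from compound 1 by methyl in place of hydrogen on an aromatic carbon (methyl in place of hydrogen on an aromatic carbon, ortho to a large group, meta to a chloro group). Going by the values given here, the one measured step on this aromatic ring, a 41-fold higher number from compound 1 to compound 2 (1.61 log units; beyond the scatter), is large, yet it removes the chloro group and no methyl step has been measured. A modest rise in this assay is therefore expected, with no change beyond the scatter also possible. The expected step is a 1.8-fold higher number from compound 1 to compound 4 (0.25 log units; within the scatter) (estimated). Compound 4 is expected at 90 nM (estimated range 25 nM to 350 nM).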

Compound 4, half-maximal inhibitory concentration: 85.1 nM
For compound 4 the middle estimate is 1.1-fold (0.02 log units) above the measured one; the range from low to high includes it.
By their numbers in this assay, from the lowest: compounds 1, 4 and 3 (each within the scatter of the next, the first and the last beyond it); then compound 2.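

In this assay methyl in place of hydrogen on an aromatic carbon, ortho to a large group and meta to a chloro group, gives a 1.7-fold higher number from compound 1 to compound 4 (0.23 log units; within the scatter) and so leaves the number within the scatter. Going by these compounds alone, the earlier compounds showed this ring only through loss of the chloro group, a 41-fold higher number from compound 1 to compound 2 (1.61 log units; beyond the scatter) being the sole step, whereas this position accepts an added methyl with the chloro group kept. No measured evidence accounts for this step.

On these data alone, whether an ethyl, methoxy or fluoro group at this position would also stay within the scatter of compound 1 remains open. Also open, as far as these compounds go, is how the methyl would read without the chloro group.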